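The compounds below may be only part of what the source reports. "The series", "measured", "known", "first", "only" and "open" are said of these compounds alone.

Compound 3 `[C-]#[N+]C[C@H]1OC(n2cc(C)c(=O)[nH]c2=O)C[C@H]1N=[N+]=[N-]` is one of three measured compounds sharing the same core. In a functional assay on MT4 cells (Homo sapiens) (on this read-out higher numbers stand for lower toxicity in this test and lower numbers for higher toxicity in this test), compound 3 gives 122000 nM. Compound 1 `[C-]#[N+]C[C@H]1OC(n2cc(C)c(=O)[nH]c2=O)C[C@H]1O` gives 144000 nM and compound 2 `[C-]#[N+]C[C@H]1OC(n2ccc(=O)[nH]c2=O)C[C@H]1O` gives 125000 nM; the number for compound 3 lies within the usual scatter of both, so none of the three can be set apart from the others.

Compound 4 `[C-]#[N+]C[C@H]1OC(n2ccc(=O)[nH]c2=O)C[C@H]1N=[N+]=[N-]` differs from compound 3 by hydrogen in place of methyl on an aromatic carbon. The same exchange has been seen once already, and there a 1.2-fold lower number from compound 1 to compound 2 (0.06 log units; within the scatter). That single step carries over directly, so in this assay no step beyond the scatter is expected a 1.1-fold lower number from compound 3 to compound 4 (0.03 log units; within the scatter). Compound 4 is therefore estimated at 115000 nM, with a range from 65000 nM to 200000 nM.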

Compound 4, half-maximal cytotoxic concentration: 104000 nM
For compound 4 the middle estimate is 1.1-fold (0.04 log units) above the measured one; the range from low to high includes it.
By their numbers in this assay, from the lowest: compounds 4, 3, 2 and 1 (each within the scatter of the next).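

Hydrogen in place of methyl on this aromatic carbon gives a 1.2-fold lower number from compound 3 to compound 4 (0.07 log units; within the scatter) with azido on the saturated ring carbon, so in this assay this exchange stays within the scatter on a second core: the same change on two cores in this assay, a 1.2-fold lower number (0.06 log units; within the scatter) from compound 1 to compound 2 and a 1.2-fold lower number (0.07 log units; within the scatter) from compound 3 to compound 4, 1.0-fold (0.01 log units) apart, within the scatter of two such steps. Azido in place of hydroxy, now read without the methyl, gives a 1.2-fold lower number from compound 2 to compound 4 (0.08 log units; within the scatter) and likewise repeats: the same change on two cores in this assay, a 1.2-fold lower number (0.07 log units; within the scatter) from compound 1 to compound 3 and a 1.2-fold lower number (0.08 log units; within the scatter) from compound 2 to compound 4, 1.0-fold (0.01 log units) apart, within the scatter of two such steps. Neither change therefore moves this read-out beyond the scatter on either core. Still open, as far as these compounds go, is whether an ethyl group or a bromine atom on this aromatic carbon would do so. The same question stands for an amine in place of the azido group.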